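The source may report more compounds than this note shows. Statements on the series, on what has been measured and on what is new or still open speak of the compounds shown alone.

Measured so far, in an ADME assay on cells (Hepatocyte, Rattus norvegicus) for metabolic stability; on this read-out lower numbers stand for slow clearance and higher numbers for fast clearance:

compound 1 `Cc1ccc2[nH]c(C(=O)N[C@H]3CN(S(=O)(=O)c4ccnnc4)C[C@@H]3C(=O)NCCN(C)C)cc2c1`: 2 uL/min
compound 2 `Cc1ccc2[nH]c(C(=O)N[C@H]3CN(S(=O)(=O)c4ccccc4)C[C@@H]3C(=O)NC[C@H]3CCCN3)cc2c1`: 10 uL/min

Of the two numbers, compound 2 carries the higher one; the gap from compound 1 to compound 2 lies beyond the usual scatter of this assay, so the two are read as genuinely different. Going by the values given here, no single-point step between measured compounds is available, and compound 1 and compound 2 differ at more than one place, so nothing is said here about which part of the structure carries that gap.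

Compound 3 `Cc1ccc2[nH]c(C(=O)N[C@H]3CN(S(=O)(=O)c4ccccc4)C[C@@H]3C(=O)N[C@@H]3CCCNC3)cc2c1` is the next entry for this assay. It keeps every atom of compound 2 and rearranges only the amine-bearing group on the amide-type nitrogen: piperidin-3-yl in place of (pyrrolidin-2-yl)methyl on an amide-type nitrogen. The ring grows by one member while the connecting methylene is taken into it, and donor and acceptor counts stay as before.

Among the compounds with values here, with no measured pair to lean on, the expected step in this assay from compound 2 to compound 3 is none beyond the scatter, no change at the digits printed from compound 2 to compound 3 (within the scatter). Compound 3 is therefore estimated at 10 uL/min, within 4 uL/min to 25 uL/min.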

Compound 3, intrinsic clearance in a liver preparation (reported as CLH), per the amount of preparation that the assay uses: 9 uL/min
For compound 3 the middle estimate is 1.1-fold (0.05 log units) above the measured one; measured number inside the range.
By their numbers in this assay, from the lowest: compound 1; then compounds 3 and 2 (each within the scatter of the next).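

Going by these compounds alone, this is the first step that changes a single place: in this assay, piperidin-3-yl in place of (pyrrolidin-2-yl)methyl on an amide-type nitrogen gives a 1.1-fold lower number from compound 2 to compound 3 (0.05 log units; within the scatter) and so leaves the two groups indistinguishable on this read-out. At this position, with the rest of the structure held as in compound 2, taking the connecting methylene into a six-membered non-aromatic ring therefore registers as no real difference from the five-membered ring on its methylene, although this rests on one pair alone. No measurement at hand bears on why the read-out stays in place.

From the compounds shown here alone, it remains open whether the same holds for a different amine-bearing group on this nitrogen, such as an azetidine, a morpholine or a piperazine, or for a non-amine group such as a carboxylic acid. Also open, going by these compounds, is whether the equivalence of these two groups would survive a change elsewhere in the structure, or the opposite stereocentre in the piperidin-3-yl group.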